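The source may report more compounds than this note shows. Statements on the series, on what has been measured and on what is new or still open speak of the compounds shown alone.

Within the data shown here, in an assay for inhibition of protein disulfide-isomerase (Homo sapiens), with a stated time of 1 h (on this read-out lower numbers stand for stronger inhibition and higher numbers for weaker inhibition), three compounds have numbers so far. Compound 1 `Cc1ccc(C)c(C(Nc2ccccn2)c2ccc3cccnc3c2O)c1` gives 730 nM, compound 2 `Oc1ccc2[nH]ncc2c1C(c1ccc(-n2cccc2)cc1)N1CCCCC1` gives 290 nM, and compound 3 `COc1ccc(C(Nc2cc(C)ccn2)c2ccc3cccnc3c2O)cc1O` gives 150 nM. Compound 3 carries the lowest number of the three, but its gap to compound 2 lies within the usual scatter of repeated measurements, so the two cannot be placed in any order; only compound 1 stands apart, with a number beyond the scatter above that of compound 3.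

Compound 4 `Cc1ccnc(NC(c2ccc(F)cc2)c2ccc3cccnc3c2O)c1` has not yet been measured. It differs from compound 3 in a single place: 4-fluorophenyl in place of 3-hydroxy-4-methoxyphenyl on a saturated chain carbon bound to an aromatic carbon and a nitrogen on an aromatic ring. In plain terms, the group that leaves carries one hydrogen-bond donor and two hydrogen-bond acceptors, while the 4-fluorophenyl that enters carries none. Among the measured compounds shown here, no pair of measured compounds shows this exact change on its own, so there is no direct step to lean on; compound 1 differs from compound 3 in more than one place and can serve only as a loose hint that a different aryl group can go with a higher number.

The step in this assay from compound 3 to compound 4 is expected to be modest and toward weaker inhibition, a 2.7-fold higher number from compound 3 to compound 4 (0.43 log units; beyond the scatter). Compound 4 is therefore estimated at 400 nM, within a range from 150 nM to 1100 nM.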

Compound 4, half-maximal inhibitory concentration: 140 nM
Beside the measured number, compound 4's estimate is 2.9-fold (0.46 log units) above it, outside the stated range (below it).
By their numbers in this assay, from the lowest: compounds 4, 3 and 2 (each within the scatter of the next, the first and the last beyond it); then compound 1.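

Among these compounds, a step of a 1.1-fold lower number from compound 3 to compound 4 (0.03 log units; within the scatter) in this assay is the first single-place comparison, and it lies within the usual scatter of repeated measurements. On a saturated chain carbon bound to an aromatic carbon and a nitrogen on an aromatic ring, 4-fluorophenyl can therefore take the place of 3-hydroxy-4-methoxyphenyl with no difference that this read-out can resolve, even though the entering group has none of the hydrogen-bond donors or acceptors counted on the leaving group, so for this pair those donors and acceptors are not required for a number in this range. Nothing given here explains why the two numbers stand so close.

This single pair cannot tell whether the hydroxy and methoxy groups would matter if each were changed alone, or whether the same swap would give a similar result on another core, such as that of compound 1. It also leaves open how this position would respond to a carboxylic acid or an amine on the phenyl ring in place of the fluorine.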